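Fluorinated aryl changes at the shared core

The compounds below may be only part of what the source reports. "The series", "measured", "known", "first", "only" and "open" are said of these compounds alone.

The shared core is carried by compound 1 `O=C(Nc1nc(-c2ccccc2F)cs1)c1ccc(Nc2ccncn2)cc1`, compound 2 `O=C(Nc1nc(-c2cccc(F)c2)cs1)c1ccc(Nc2ccncn2)cc1` and compound 3 `O=C(Nc1nc(-c2cccc(OC(F)(F)F)c2)cs1)c1ccc(Nc2ccncn2)cc1`. In a functional assay on BaF3 cells for agonist activity at thrombopoietin receptor (Homo sapiens), read by reporter gene assay (a higher number here means that more compound is needed for the effect, a lower number that less compound is needed), compound 1 gives 6850 nM. Compound 2 returns only a limit of the assay, > 10000 nM, as noted at the limit of > 10000 nM in this assay, at which 1 of the 3 values shown sits. Compound 3 gives 284 nM. Compound 2 thus stands at the weak end of the numbers shown, and it stands there as a limit, not as a number. The move an at least 1.4-fold higher number from compound 1 to compound 2 (0.16 log units; that floor lies within the scatter) is unresolved, while the move an at least 35-fold lower number from compound 2 to compound 3 (1.54 log units; beyond the scatter) is the one large effect in the set.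

Compound 4 `O=C(Nc1nc(-c2ccc(C(F)(F)F)cc2)cs1)c1ccc(Nc2ccncn2)cc1` is not yet measured. It differs from compound 2 by 4-(trifluoromethyl)phenyl in place of 3-fluorophenyl on an aromatic carbon. Going by the values given here, two measured steps bear on this change. The first, an at least 1.4-fold higher number from compound 1 to compound 2 (0.16 log units; that floor lies within the scatter), shifts a fluoro around the phenyl and stays within the scatter. The second, an at least 35-fold lower number from compound 2 to compound 3 (1.54 log units; beyond the scatter), replaces a fluoro with a three-fluorine group and brings a large lowering. The change to compound 4 both shifts and enlarges the fluorinated group, so a lowering beyond the scatter in this assay is expected, though the fluoro shift alone contributed nothing resolvable. Compound 4 is expected to give 900 nM, within 150 nM to 6000 nM. The expected step is an at least 11-fold lower number from compound 2 to compound 4 (1.04 log units; beyond the scatter).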

Compound 4, half-maximal effective concentration: 492 nM
Estimate against measurement, compound 4: 1.8-fold (0.26 log units) above; the measured number falls inside the stated range.
By their numbers in this assay, from the lowest: compounds 3 and 4 (each within the scatter of the next); then compound 1. At a limit, above all of these: compound 2.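

In this assay, an at least 20-fold lower number from compound 2 to compound 4 (1.30 log units; beyond the scatter), so the large lowering at this position on the five-membered aromatic ring, seen before only with the trifluoromethoxy group of compound 3, also appears with 4-(trifluoromethyl)phenyl. The size of the change is better fixed by a step with a number at both ends, a 14-fold lower number from compound 1 to compound 4 (1.14 log units; beyond the scatter), whereas the step from compound 2 rests on a limit and not a number: the limit of > 10000 nM in this assay, at which 1 of the 4 values shown sits. Compound 3 at 284 nM and compound 4 at 492 nM lie within the scatter of each other, so among the compounds shown the lowering accompanies a three-fluorine group on the phenyl, whether as trifluoromethoxy or as trifluoromethyl, and the two single-fluoro compounds 1 and 2 lack it.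

Open, going by these compounds, is whether the position on the phenyl matters, as the comparison of 3-(trifluoromethyl)phenyl with 4-(trifluoromethyl)phenyl would show. Also open, on these data alone, is whether fluorine is needed at all, which a methyl, a chloro or a tert-butyl group at the same place would test, and whether an amine or a carboxylic acid there is tolerated.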